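The source may report more compounds than this note shows. Statements on the series, on what has been measured and on what is new or still open speak of the compounds shown alone.

Measured so far in a functional assay on HCT-116 cells (Homo sapiens) for antiproliferative activity, read by MTT assay, with a stated time of 72 h; on this read-out lower numbers stand for stronger inhibition and higher numbers for weaker inhibition:
Compound 1 `O=C1O/C(=C\Cn2cc(-c3ccc(Br)cc3)nn2)C(OCc2ccccc2)=C1OCc1ccccc1` gives > 100000 nM, a limit of the assay.
Compound 2 `CCCCCc1ccc(-c2cn(C/C=C3\OC(=O)C(OCc4ccccc4)=C3OCc3ccccc3)nn2)cc1` gives > 100000 nM, a limit of the assay.
Compound 3 `O=C1O[C@H]([C@@H](O)Cn2cc(CNS(=O)(=O)c3ccc(F)cc3)nn2)C(OCc2ccccc2)=C1OCc1ccccc1` gives 22900 nM.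

Going by the values given here, compound 3 stands as the only numerical value in this assay; the other two values are limits (the limit of > 100000 nM in this assay, at which 2 of the 3 values shown sit). The step from compound 1 to compound 2, a step that the two limits leave unreadable from compound 1 to compound 2, is pentyl in place of bromo and cannot be read. Compound 4 `Cc1ccc(-c2cn(C[C@H](O)[C@H]3OC(=O)C(OCc4ccccc4)=C3OCc3ccccc3)nn2)cc1` differs from compound 3 by 4-methylphenyl in place of (((4-fluorophenyl)sulfonyl)amino)methyl on an aromatic carbon. Among the compounds with values here, no measured step covers this change; compound 1 and compound 2, which also carry an aryl group on the five-membered ring, both sit at the limit. Compound 4 is therefore expected to be weaker, an estimated step of a 2.6-fold higher number from compound 3 to compound 4 (0.42 log units; beyond the scatter), giving about 60000 nM in this assay, with a range of 15000 nM to 200000 nM.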

Compound 4, half-maximal inhibitory concentration: > 100000 nM
Compound 4 was reported as a limit; the forecaster's own chance of this, stated with the estimate: 40%; middle value at least 1.6-fold (0.22 log units) from the limit.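

In this assay, 4-methylphenyl in place of (((4-fluorophenyl)sulfonyl)amino)methyl on the aromatic carbon of the five-membered ring gives an at least 4.3-fold higher number from compound 3 to compound 4 (0.64 log units; beyond the scatter). Going by these compounds alone, this is the first readable step at this position, and it shows that the position is sensitive to the change. The value of compound 4 is a limit, so the step has a lower bound only: the limit of > 100000 nM in this assay, at which 3 of the 4 values shown sit.

Which part of the leaving group matters remains open. Also open, as far as these compounds go, is whether a simple aminomethyl or a carboxylic acid on the same carbon would give a number in this assay.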